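This account rests on a few compounds, and the source may have more. Where it says the series, first, only, none or still open, it means among the compounds named here.

Measured in a functional assay on KARPAS-422 cells (Homo sapiens) for antiproliferative activity, read by resazurin assay, with a stated time of 72 h; on this read-out lower numbers stand for stronger inhibition and higher numbers for weaker inhibition:
- Compound 1 `Cc1cc(C)c(CN2CCc3c(Cl)cc([C@H](CO)[C@H]4CCOC4)c(Cl)c3C2=O)c(=O)[nH]1`: 15 nM
- Compound 2 `COC(c1cc(Cl)c2c(c1Cl)C(=O)N(Cc1c(C)cc(C)[nH]c1=O)CC2)C1CCOC1`: 175 nM; 406 nM; 50 nM; 25 nM (4 entries)
- Compound 3 `Cc1cc(C)c(CN2CCc3c(Cl)cc([C@H](CO)[C@H]4CCCO4)c(Cl)c3C2=O)c(=O)[nH]1`: 63 nM

Of the two compounds with a single number, compound 3 stands higher, which means weaker: a 4.2-fold higher number from compound 1 to compound 3 (0.62 log units; beyond the scatter). Compound 2 has no single number, and its readings spread widely: the several entries of compound 2 in this assay, 175 nM; 406 nM; 50 nM; 25 nM (4 entries).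

Compound 4 `Cc1cc(C)c(CN2CCc3c(Cl)cc([C@@H](CO)[C@@H]4CCOC4)c(Cl)c3C2=O)c(=O)[nH]1` is still unmeasured. Its change from compound 3 is a group of 8 heavy atoms (6 carbon, 2 oxygen; one five-membered non-aromatic ring with 1 hetero atom) in place of a group of 8 heavy atoms (6 carbon, 2 oxygen; one five-membered non-aromatic ring with 1 hetero atom), on an aromatic carbon. Compound 4 carries oxolan-3-yl, as compound 1 does, but its two defined stereocentres are set differently from those of compound 1. Going by the values given here, the only measured guide is a 4.2-fold higher number from compound 1 to compound 3 (0.62 log units; beyond the scatter), and it points to a lower number only in part. No clear shift is therefore expected in this assay. The expected change is a 1.3-fold higher number from compound 3 to compound 4 (0.10 log units; within the scatter). For compound 4 the estimated value is 80 nM, within an expected range of 15 nM to 500 nM.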

Compound 4, half-maximal inhibitory concentration: 3950 nM
Compound 4: the middle estimate sits 49-fold (1.69 log units) below what was measured, and the stated range ends below it.
By their numbers in this assay, from the lowest: compound 1; then compound 3; then compound 4.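

At this position, the arrangement in space alone can cost a very large loss of activity in this assay, with a 260-fold higher number from compound 1 to compound 4 (2.42 log units; beyond the scatter). This loss comes from configuration and nothing else, because of this: the fact that compounds 1 and 4 differ only in the configuration as drawn. Changing the ring attachment to oxolan-2-yl costs far less than this inversion, as compound 3 still stands well ahead of the mirror image, with a 63-fold higher number from compound 3 to compound 4 (1.80 log units; beyond the scatter).

From the compounds shown here alone, both stereocentres are inverted together, so which of them carries the loss remains open. Also open, going by these compounds, is how an aminomethyl group would behave in place of the hydroxymethyl group.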